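Methylating the hydroxymethyl piperidine of the chlorophenyl analogue

The compounds below may be only part of what the source reports. "The series", "measured", "known", "first", "only" and "open" are said of these compounds alone.

Compound 1 `COc1cc2nc(N3CCC(N4CCCC(CO)C4)CC3)nc(NCCCc3ccc(Cl)cc3)c2cc1OC` gives 180 nM in an in vitro functional assay on B300-19 cells for antagonist activity at C-C chemokine receptor type 4 (Homo sapiens), read by GTPgammaS binding; on this read-out lower numbers stand for stronger inhibition and higher numbers for weaker inhibition. Compound 2 `COc1cc2nc(N3CCC(N4CCCC(CO)C4)CC3)nc(Nc3ccc(Cl)cc3)c2cc1OC` gives 19 nM in this assay, the lowest of the two numbers; the step of a 9.5-fold lower number from compound 1 to compound 2 (0.98 log units; beyond the scatter) lies beyond the scatter. Within the data shown here, compound 3 `COCC1CCCN(C2CCN(c3nc(Nc4ccc(Cl)cc4)c4cc(OC)c(OC)cc4n3)CC2)C1` differs from compound 2 by methyl in place of hydrogen on an oxygen on a saturated carbon, a change on the 3-(hydroxymethyl)piperidin-1-yl group and not at the nitrogen on an aromatic ring where the one measured step acts. Among the measured compounds shown here, no measured step bears on this change, so for compound 3 in this assay a step within the scatter is expected, a 1.3-fold higher number from compound 2 to compound 3 (0.12 log units; within the scatter). Compound 3 is estimated at 25 nM, with a range from 9 nM to 70 nM.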

Compound 3, half-maximal inhibitory concentration: 52 nM
Beside the measured number, compound 3's estimate is 2.1-fold (0.32 log units) below it; measured number inside the range.
By their numbers in this assay, from the lowest: compound 2; then compound 3; then compound 1.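

In this assay, the 3-(hydroxymethyl)piperidin-1-yl group proves sensitive to change: hydroxy to methoxy gives a 2.7-fold higher number from compound 2 to compound 3 (0.44 log units; beyond the scatter). Among these compounds, this is the first measured change on this group, made with the 4-chlorophenyl on the aromatic-ring nitrogen held constant, and a single methyl on the oxygen is enough to move the number beyond the scatter. Nothing available accounts for this step.

The compounds shown do not settle whether a free hydroxy is specifically favoured. As far as these compounds go, an amine or a carboxylic acid in place of the hydroxy, or an ethyl on the oxygen, remains open.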